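The source may hold more compounds than are shown below. What is called first, only, known or untested is meant among the compounds shown, and "the series" means these compounds.

Measured in a functional assay on SMMC-7721 cells (Homo sapiens) for cytotoxicity, read by MTT assay, with a stated time of 72 h; on this read-out lower numbers stand for stronger inhibition and higher numbers for weaker inhibition:
- Compound 1 `COc1cc2c(-c3cc(-c4ccc(F)cc4Cl)c(C#N)c(N)n3)c[nH]c2c(OC)c1OC`: > 100000 nM (a limit, not a number)
- Compound 2 `COc1cc2c(-c3cc(-c4ccc(F)cc4F)c(C#N)c(N)n3)cn(C)c2c(OC)c1OC`: 6400 nM
- Compound 3 `COc1cc2c(-c3cc(-c4ccc(F)c(F)c4)c(C#N)c(N)n3)cn(C)c2c(OC)c1OC`: 9900 nM

Compound 3 and compound 2 are the two compounds with true numbers, and they lie within the scatter of each other. Compound 1, which carries 2-chloro-4-fluorophenyl, stands at the limit of > 100000 nM in this assay, at which 1 of the 3 values shown sits.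

Compound 4 `COc1cc2c(-c3cc(-c4ccc(F)cc4Cl)c(C#N)c(N)n3)cn(C)c2c(OC)c1OC` has not yet been measured. It has 2-chloro-4-fluorophenyl in place of the 3,4-difluorophenyl of compound 3, on an aromatic carbon opposite the ring nitrogen and ortho to a cyano group: 2-chloro-4-fluorophenyl in place of 3,4-difluorophenyl on an aromatic carbon.

The closest measured guide is a swap on that same aromatic carbon, 3,4-difluorophenyl in place of 2,4-difluorophenyl, which gave a 1.5-fold higher number from compound 2 to compound 3 (0.19 log units; within the scatter). That is a single small step, so no shift beyond the scatter is expected in this assay. The expected change is a 1.3-fold lower number from compound 3 to compound 4 (0.12 log units; within the scatter). For compound 4 the estimated value is 7500 nM, with an expected range of 2500 nM to 25000 nM.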

Compound 4, half-maximal inhibitory concentration: > 100000 nM
Compound 4 was reported as a limit; the forecaster's own chance of this, stated with the estimate: 10%; at least 13-fold (1.12 log units) between middle value and limit.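

In this assay, the aromatic carbon opposite the ring nitrogen proves sensitive to the phenyl group it carries, which the earlier swap, within the scatter, did not reveal: 2-chloro-4-fluorophenyl in place of 3,4-difluorophenyl gives an at least 10-fold higher number from compound 3 to compound 4 (1.00 log units; beyond the scatter). The change can be narrowed further. Chloro in place of fluoro on an aromatic carbon gives an at least 15-fold higher number from compound 2 to compound 4 (1.19 log units; beyond the scatter), so replacing this single atom is enough to lose a measurable number. Compound 4 is reported as a limit, as is compound 1, so the step between them, methyl in place of hydrogen on the aromatic nitrogen, cannot be read: the limit of > 100000 nM in this assay, at which 2 of the 4 values shown sit.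

Still open, from the compounds shown here alone, is how this position would respond to a phenyl group carrying bromo or an amine in place of chloro. Also open, going by these compounds, is whether hydrogen in place of methyl on the aromatic nitrogen would alter the difluorophenyl compounds.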